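This account rests on a few compounds, and the source may have more. Where it says the series, first, only, none or still open, it means among the compounds named here.

Compound 3 `CC1=CC[C@H](C(C)(C)NC(=S)N/N=C/c2cccc(Cl)c2)CC1` is, on the three numbers in hand, the second highest: in a functional assay on OVCAR-3 cells (Homo sapiens) for inhibition, read by sulforhodamine B assay, with a stated time of 48 h (on this read-out higher numbers stand for weaker inhibition of growth and lower numbers for stronger inhibition of growth), compound 3 gives 13600 nM. Its nearest neighbour is compound 2 `CC1=CC[C@H](C(C)(C)NC(=S)N/N=C/c2ccccc2Cl)CC1`, which in this assay gives 15100 nM; the step of a 1.1-fold lower number from compound 2 to compound 3 (0.05 log units; within the scatter) is within the scatter. Furthest from it is compound 1 `CC1=CC[C@H](C(C)(C)NC(=S)N/N=C/c2ccccc2O)CC1`, which in this assay gives 5500 nM; the steps of a 2.5-fold higher number from compound 1 to compound 3 (0.39 log units; beyond the scatter) and a 2.7-fold higher number from compound 1 to compound 2 (0.44 log units; beyond the scatter) are both beyond the scatter.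

Compound 4 `CC1=CC[C@H](C(C)(C)NC(=S)N/N=C/c2ccc[nH]2)CC1` differs from compound 3 in one place: 1H-pyrrol-2-yl in place of 3-chlorophenyl on a carbon with a double bond to nitrogen. The measured steps that bear on it are the two that change the group on the same carbon, namely a 2.5-fold higher number from compound 1 to compound 3 (0.39 log units; beyond the scatter) and a 1.1-fold lower number from compound 2 to compound 3 (0.05 log units; within the scatter). For the measured compounds named here, they show that swapping a chlorophenyl for a chlorophenyl changed little, while the only group carrying a hydrogen-bond donor, in compound 1, went with a modestly lower number. Going by the values given here, since the entering 1H-pyrrol-2-yl also carries one hydrogen-bond donor, a modest step towards a lower number is expected in this assay, though no measured step tests a five-membered ring here, so the expectation is loose. The step expected from compound 3 to compound 4 is a 1.7-fold lower number from compound 3 to compound 4 (0.23 log units; within the scatter), and compound 4 is estimated at 8000 nM, between 3000 nM and 22000 nM.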

Compound 4, concentration for 50% growth inhibition: 33500 nM
The estimate for compound 4 lay 4.2-fold (0.62 log units) below the measured number; the whole stated range lies below it.
By their numbers in this assay, from the lowest: compound 1; then compounds 3 and 2 (each within the scatter of the next); then compound 4.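

On the carbon with a double bond to nitrogen, the 1H-pyrrol-2-yl group gives the highest number of the four in this assay: a 2.5-fold higher number from compound 3 to compound 4 (0.39 log units; beyond the scatter), a 2.2-fold higher number from compound 2 to compound 4 (0.35 log units; beyond the scatter) and a 6.1-fold higher number from compound 1 to compound 4 (0.78 log units; beyond the scatter), so the weakest inhibition of growth in this set lies with compound 4. A hydrogen-bond donor in this group therefore does not by itself go with a lower number, since compound 1 and compound 4 both carry one and stand at the two ends of the order, and the span at this position is wider than the three substituted phenyl groups alone showed. No measurement given here offers a reason for this rise.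

The compounds shown leave open whether the rise goes with the five-membered ring or with the ring nitrogen and its hydrogen, and a furan-2-yl or a plain phenyl group on this carbon would bear on that. They also leave open whether the lower number of compound 1 depends on the hydroxy group standing as in 2-hydroxyphenyl, which a 3-hydroxyphenyl or a 2-methoxyphenyl group would test.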